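Compound 2 and a bromo swap

The source may hold more compounds than are shown below. What is called first, only, known or untested is meant among the compounds shown, and "the series" means these compounds.

Measured in a functional assay on NALM-6 cells (Homo sapiens) for cytotoxicity, read by MTT assay, with a stated time of 46 h; a higher number here means a weaker inhibitor, a lower number a stronger inhibitor:
Compound 1 `O=C1/C(=C\c2ccncc2)C(c2ccccc2)Oc2ccccc21`: 700 nM
Compound 2 `Cc1ccc(/C=C2\C(=O)c3ccccc3OC2c2ccccc2)cc1`: > 1000000 nM (a limit, not a number)
Compound 3 `Cc1ccc(/C=C2/C(=O)c3ccccc3OC2c2ccccc2)cc1`: 51400 nM

Compound 2 stands at the weak end of this set. In this assay compound 2 gives > 1000000 nM, which is a limit of the assay and not a number.

Compound 4 `O=C1/C(=C\c2ccc(Br)cc2)C(c2ccccc2)Oc2ccccc21` differs from compound 2 in one place: bromo in place of methyl on an aromatic carbon. Cut one bond further out, this reads 4-methylphenyl to 4-bromophenyl.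

Among the measured compounds shown here, two measured steps bear on this only loosely. Exchanging the whole group that carries this substituent gave an at least 1400-fold higher number from compound 1 to compound 2 (3.15 log units; beyond the scatter). Changing the double bond geometry gave an at least 19-fold lower number from compound 2 to compound 3 (1.28 log units; beyond the scatter). Both are large, but neither swaps methyl for bromo, so the size of this step is unmeasured. Starting from a limit, only a lower number or another limit can appear.

A moderate move towards a lower number in this assay is expected, and the estimated step is an at least 20-fold lower number from compound 2 to compound 4 (1.30 log units; beyond the scatter). For compound 4 the estimate is 50000 nM, with an expected range from 5000 nM to 500000 nM.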

Compound 4, half-maximal inhibitory concentration in the NALM-6 assay: > 1000000 nM
Compound 4 gave a limit, no number; the forecaster's own chance of this, stated with the estimate: 25%; middle value at least 20-fold (1.30 log units) from the limit.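

In the NALM-6 assay, compound 4 gives > 1000000 nM, which is a limit of the assay and not a number. In the NALM-6 assay, compound 2 gives > 1000000 nM, which is also a limit and not a number. The step between them cannot be read, and bromo in place of methyl gives no measurable gain at this position: the limit of > 1000000 nM in the NALM-6 assay, at which 2 of the 4 values shown sit.

Replacing pyridin-4-yl with 4-bromophenyl in the NALM-6 assay gives an at least 1400-fold higher number from compound 1 to compound 4 (3.15 log units; beyond the scatter), so 4-bromophenyl matches 4-methylphenyl in falling to the limit. A reading based on the group alone does not hold, however: in the NALM-6 assay, compound 3 carries 4-methylphenyl and still gives 51400 nM. The swap does register in a physicochemical assay for lipophilicity, read by HPLC (on this read-out lower numbers stand for lower lipophilicity and higher numbers for higher lipophilicity), where compound 2 gives 4.39 and compound 4 gives 4.71, which shows a number 0.32 log units higher from compound 2 to compound 4 (beyond the scatter).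

As far as these compounds go, how far compound 2 and compound 4 lie beyond their limit stays open, as does the value of 4-bromophenyl with the double bond geometry of compound 3. Also open, from the compounds shown here alone, is how an amine or a carboxylic acid would behave at this position.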